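The source may report more compounds than this note shows. Statements on the series, on what has been measured and on what is new or still open speak of the compounds shown alone.

Values in a functional assay on MCF7 cells (Homo sapiens) for antiproliferative activity, read by MTT assay, with a stated time of 48 h; a higher number here means a weaker inhibitor, a lower number a stronger inhibitor:
compound 1 `COC/C1=C/C[C@](C)(CCC=C(C)C)/C=C/[C@@H](OC(=O)C=C(C)C)[C@](C)(O)/C=C/C1=O` gives 4130 nM
compound 2 `CC(C)=CCC[C@]1(C)/C=C/[C@@H](OC(=O)C=C(C)C)[C@](C)(O)/C=C/C(=O)/C(CCl)=C\C1` gives 610 nM
compound 3 `CC(C)=CCC[C@]1(C)/C=C/[C@@H](OC(=O)C=C(C)C)[C@](C)(O)/C=C/C(=O)/C(CN(C(C)C)C(C)C)=C\C1` gives 780 nM

Compound 3 cannot be separated from compound 2 (a 1.3-fold higher number from compound 2 to compound 3 (0.11 log units; within the scatter)). Both stand below compound 1 (a 5.3-fold lower number from compound 1 to compound 3 (0.72 log units; beyond the scatter); a 6.8-fold lower number from compound 1 to compound 2 (0.83 log units; beyond the scatter)).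

Compound 4 `CC(C)=CCC[C@]1(C)/C=C/[C@@H](OC(=O)C=C(C)C)[C@](C)(O)/C=C/C(=O)/C(CN2CCN(C)CC2)=C\C1` is still unmeasured. It carries 4-methylpiperazin-1-yl in place of diisopropylamino on a saturated chain carbon bound to a double-bonded ring carbon.

All three measured steps were made at this same place. The exchange of chloro for diisopropylamino stayed within the scatter (a 1.3-fold higher number from compound 2 to compound 3 (0.11 log units; within the scatter)), while the modest steps both start from the methoxy of compound 1 (a 6.8-fold lower number from compound 1 to compound 2 (0.83 log units; beyond the scatter); a 5.3-fold lower number from compound 1 to compound 3 (0.72 log units; beyond the scatter)). Within the data shown here, no measured compound carries a ring at this place, so the range is kept wide, and in this assay no step beyond the scatter is expected.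

The estimated step is small (a 1.0-fold higher number from compound 3 to compound 4 (0.01 log units; within the scatter)).

For compound 4 the expected value is about 800 nM (estimated range 350 nM to 2000 nM).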

Compound 4, half-maximal inhibitory concentration: 550 nM
Compound 4: the middle estimate sits 1.5-fold (0.16 log units) above what was measured; the range from low to high includes it.
By their numbers in this assay, from the lowest: compounds 4, 2 and 3 (each within the scatter of the next); then compound 1.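

In this assay, a ring at this place on a saturated chain carbon bound to a double-bonded ring carbon is tolerated: 4-methylpiperazin-1-yl matches the open-chain amine (a 1.4-fold lower number from compound 3 to compound 4 (0.15 log units; within the scatter)) and the chloro group (a 1.1-fold lower number from compound 2 to compound 4 (0.04 log units; within the scatter)). The separation from the methoxy group also holds with the ring in place (a 7.5-fold lower number from compound 1 to compound 4 (0.88 log units; beyond the scatter)), so among these four compounds, methoxy alone stands apart, while three quite different groups cannot be told apart. No supporting data bear on why this position behaves in this way.

The compounds shown leave open whether morpholin-4-yl or a free hydroxyl at this place would group with compound 1 or with the other three. They also leave open whether a carboxylic acid or a longer chain between the ring carbon and the amine would keep this level.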